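Thiosemicarbazone series: swapping the aryl group on the imine carbon

A few compounds are considered here, and "the series" means these few. Any claim that something is new, unique, unknown or untested is made for them only; others in the source may bear on it.

In a functional assay on 786-0 cells (Homo sapiens) for inhibition, read by sulforhodamine B assay, with a stated time of 48 h (on this read-out lower numbers stand for stronger inhibition of growth and higher numbers for weaker inhibition of growth), compound 1 `COc1ccc(/C=N/NC(=S)NC(C)(C)[C@H]2CC=C(C)CC2)cc1` gives 29600 nM. Compound 2 `CC1=CC[C@H](C(C)(C)NC(=S)N/N=C/c2ccc(F)cc2)CC1` reaches only a limit of this assay, > 100000 nM. Compound 3 `CC1=CC[C@H](C(C)(C)NC(=S)N/N=C/c2ccccc2Cl)CC1` likewise stands at a limit in this assay, > 100000 nM, so no number of its own is known for it; it sits at the limit of > 100000 nM in this assay, at which 2 of the 3 values shown sit, together with one other value. The steps of an at least 3.3-fold higher number from compound 1 to compound 2 (0.52 log units; beyond the scatter) and an at least 3.3-fold higher number from compound 1 to compound 3 (0.52 log units; beyond the scatter) both run from a measured number into that limit, and the step that the two limits leave unreadable from compound 2 to compound 3 cannot be read because both of its ends rest on (the limit of > 100000 nM in this assay, at which 2 of the 3 values shown sit).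

Compound 4 `CC1=CC[C@H](C(C)(C)NC(=S)N/N=C/c2ccc[nH]2)CC1` differs from compound 3 by 1H-pyrrol-2-yl in place of 2-chlorophenyl on a carbon with a double bond to nitrogen. Going by the values given here, of the measured steps, only the one from compound 1 to compound 3 is of the same kind, a change of the aryl group on the carbon with a double bond to nitrogen, and it weakened growth inhibition past the limit. Among the compounds with values here, no measured step covers a five-membered ring or a hydrogen-bond donor at that place, so the direction from compound 3 is open. Compound 4 is expected to stay near the limit, with an at least 1.2-fold lower number from compound 3 to compound 4 (0.09 log units; that floor lies within the scatter) as the most likely outcome. The estimate for compound 4 in this assay is 80000 nM, within 20000 nM to 150000 nM.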

Compound 4, concentration for total growth inhibition: > 100000 nM
Compound 4: no number, only a limit; the forecaster's own chance of this, stated with the estimate: 55%; middle value at least 1.2-fold (0.09 log units) from the limit.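

Compound 4 stands at a limit of this assay, > 100000 nM. Replacing 4-methoxyphenyl with 1H-pyrrol-2-yl on the carbon with a double bond to nitrogen gives an at least 3.3-fold higher number from compound 1 to compound 4 (0.52 log units; beyond the scatter), so this position now has a five-membered aromatic ring with a hydrogen-bond donor, as well as the halogenated phenyl groups of compound 2 and compound 3, without a measured number; the steps linking those two compounds to compound 4 cannot be read. Among the compounds shown, only compound 1 gives a number, and the other three aryl changes gather at one end of the read-out: the limit of > 100000 nM in this assay, at which 3 of the 4 values shown sit.

The limits leave the order of compound 2, compound 3 and compound 4 open, and one measured compound cannot show whether the methoxy group itself matters or whether 4-methoxyphenyl is simply the only tolerated aryl group among these four. From the compounds shown here alone, it also remains open how the series would respond to an ethoxy group or a longer alkoxy chain in place of that methoxy group, or to an amine or a carboxylic acid on the phenyl ring.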